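Ester to ketone on a cyclohexenyl sulfone scaffold

This account rests on a few compounds, and the source may have more. Where it says the series, first, only, none or still open, it means among the compounds named here.

Measured compounds:
compound 1, `CCOC(=O)C1=CCCCC1NS(=O)(=O)c1ccc(F)cc1Cl`, > 10000 nM
compound 2, `CCOC(=O)C1=CCCCC1S(=O)(=O)Oc1ccc(F)cc1Cl`, 904 nM
compound 3, `CCCOC(=O)C1=CCCCC1S(=O)(=O)Cc1ccc(F)cc1Cl`, 14 nM

Of the compounds shown here, three share the same core and have been tested in a functional assay on RAW264.7 cells (Mus musculus), read by fluorescence; a higher number here means a weaker inhibitor, a lower number a stronger inhibitor. Compound 1 reaches only a limit of the assay, > 10000 nM, and gives no number (the limit of > 10000 nM in this assay, at which 1 of the 3 values shown sits). Compound 2 gives 904 nM. Compound 3 gives the lowest number of the two that are numbers, 14 nM, and its gap to compound 2 lies beyond the scatter of repeated measurements; the step between them is not described here, so only the two values themselves can be compared.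

The next compound, compound 4, `CCC(=O)C1=CCCCC1S(=O)(=O)Cc1ccc(F)cc1Cl`, differs from compound 3 in one place: ethyl in place of propoxy on a carbonyl carbon. The ester of compound 3 thus becomes a ketone, and the chain on that carbonyl is shortened.

Within the data shown here, no measured pair shows this change, so the expectation rests on compound 3 alone, whose value of 14 nM is the starting point. A modest weakening is expected, a 2.9-fold higher number from compound 3 to compound 4 (0.46 log units; beyond the scatter), though a result within the scatter would not surprise. Compound 4 is therefore estimated at 40 nM, with a range from 10 nM to 200 nM.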

Compound 4, half-maximal inhibitory concentration: 64 nM
Estimate against measurement, compound 4: 1.6-fold (0.20 log units) below, and the stated range covers the measured number.
By their numbers in this assay, from the lowest: compound 3; then compound 4; then compound 2. At a limit, above all of these: compound 1.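

In this assay, among these compounds, the change from propoxycarbonyl to propanoyl gives a 4.6-fold higher number from compound 3 to compound 4 (0.66 log units; beyond the scatter), the first step that can be read at a single place. It shows that this position on the carbonyl carbon responds to the exchange of propoxy for ethyl, but that the propoxy group is not required for inhibition, as compound 4, a ketone, still gives 64 nM. Among the compounds shown here, nothing measured here explains the loss of strength, and the only supporting information concerns the assay limit reached by another compound, which has no bearing on this step.

This single step combines the removal of the oxygen with a shorter chain, so the compounds shown cannot say how much of the change belongs to each. A longer ketone chain such as butanoyl would help to separate the two, while an amide or a carboxylic acid on the same carbonyl carbon would show how this position responds to groups of a different kind.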